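The compounds below may be only part of what the source reports. "The series", "measured", "known", "first", "only" and "open" are said of these compounds alone.

Compound 3 `CCC(CC)(c1ccc(OCCCO)c(C)c1)c1ccc(OCC(O)C(C)(C)C)c(OCC(O)C(C)(C)C)c1` belongs to a group of three compounds that share one core and differ only in the chain hanging from one aromatic oxygen. In an assay on cells for binding affinity to vitamin D3 receptor (Homo sapiens), read by fluorescence, tested at 1 uM (a higher number here means more inhibition at the concentration tested (going by the name of the read-out), a lower number less inhibition), compound 3 gives 76%. That places compound 3 second highest of the three: compound 1 `CCC(CC)(c1ccc(OCC(O)CO)c(C)c1)c1ccc(OCC(O)C(C)(C)C)c(OCC(O)C(C)(C)C)c1` gives 78%, a gap within the scatter, while compound 2 `CCC(CC)(c1ccc(OCCO)c(C)c1)c1ccc(OCC(O)C(C)(C)C)c(OCC(O)C(C)(C)C)c1` gives 38%, clearly apart from the other two.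

Compound 4 `CCC(CC)(c1ccc(OCCCCO)c(C)c1)c1ccc(OCC(O)C(C)(C)C)c(OCC(O)C(C)(C)C)c1` has not yet been measured. It differs from compound 3 by hydroxymethyl in place of hydroxy on a saturated chain carbon, three bonds along the chain from an oxygen on an aromatic ring, so the chain between the aromatic oxygen and the hydroxy gains one carbon.

For the measured compounds named here, two measured steps bear on this. The step from compound 2 to compound 3, which also added one carbon to that chain, was large, a number 38 percentage points higher from compound 2 to compound 3 (beyond the scatter). The step from compound 1 to compound 3, which removed one hydroxy, lay within the scatter, a number 2 percentage points lower from compound 1 to compound 3 (within the scatter). The first step shows that one added carbon can move this assay strongly; whether a second added carbon continues, levels off or reverses cannot be read from three compounds. The expected step for compound 4 is therefore small, a number 11 percentage points lower from compound 3 to compound 4 (beyond the scatter), with wide uncertainty either way. The estimate for compound 4 in this assay is 65%, expected to fall between 35% and 90%.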

Compound 4, a percentage reported as inhibition, at one concentration (the size of the read-out at that concentration, not a potency): 71%
For compound 4 the middle estimate is 6 percentage points below the measured one; the measured number falls inside the stated range.
By their numbers in this assay, from the lowest: compound 2; then compounds 4, 3 and 1 (each within the scatter of the next).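

In this assay, lengthening 3-hydroxypropyl to 4-hydroxybutyl (a number 5 percentage points lower from compound 3 to compound 4 (within the scatter)) does not repeat the large change seen when 2-hydroxyethyl gave way to 3-hydroxypropyl (a number 38 percentage points higher from compound 2 to compound 3 (beyond the scatter)), so the second added carbon answers the question left open by the first. The longer chain also stays well apart from the shortest one (a number 33 percentage points higher from compound 2 to compound 4 (beyond the scatter)) and cannot be told apart from the branched chain that carries two hydroxy groups (a number 7 percentage points lower from compound 1 to compound 4 (within the scatter)), which shows that a second hydroxy is not needed to reach this level. Among the four compounds shown, 2-hydroxyethyl is the only chain that stands apart, and nothing here accounts for that difference.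

From the compounds shown here alone, whether the level would hold for a still longer chain, such as 5-hydroxypentyl, remains open, as does the effect of an amine or a carboxylic acid in place of the hydroxy at the end of the chain. Each number also comes from a single concentration, so these compounds may still show a stronger or weaker effect at other concentrations in ways that these readings cannot show.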